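A few compounds are considered here, and "the series" means these few. Any claim that something is new, unique, unknown or untested is made for them only; others in the source may bear on it.

Measured compounds in an ADME assay on HEL cells (Homo sapiens) for cytotoxicity, read by microscopy, with a stated time of 3 days; on this read-out lower numbers stand for higher toxicity in this test and higher numbers for lower toxicity in this test:
compound 1 `CCOC(=O)C1(Cc2ccccc2)CN(c2ccccc2)Cc2nnn(Cc3cc(OC)c(OC)c(OC)c3)c21` gives >= 100000 nM, a limit of the assay rather than a number.
compound 2 `CCOC(=O)C1(Cc2ccccc2)CN(c2ccccc2)Cc2nnn(Cc3ccc(F)cc3)c21` gives >= 100000 nM, likewise a limit.
compound 3 `CCOC(=O)C1(Cc2ccccc2)CN(c2ccccc2)Cc2nnn(Cc3cccc(Cl)c3)c21` gives > 100000 nM, also a limit.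

All three values thus rest at limits, so the steps a step that the two limits leave unreadable from compound 1 to compound 2, a step that the two limits leave unreadable from compound 1 to compound 3 and a step that the two limits leave unreadable from compound 2 to compound 3 cannot be read in size. Two of the values sit at the limit of >= 100000 nM in this assay, at which 2 of the 3 values shown sit, and one at the limit of > 100000 nM in this assay, at which 1 of the 3 values shown sits. Compound 4 `CCOC(=O)C1(Cc2ccccc2)CN(c2ccccc2)Cc2nnn(Cc3ccccc3Cl)c21` differs from compound 3 by 2-chlorophenyl in place of 3-chlorophenyl on a saturated chain carbon bound to an aromatic nitrogen. Among the measured compounds shown here, no measured step bears on this change in a readable way: every pair among compounds 1, 2 and 3 gave only limits. In this assay no step beyond the scatter is therefore expected for compound 4. The expected step of a number no higher from compound 3 to compound 4 (the limit leaves the size open) is close to none. Compound 4 is estimated at 100000 nM, within 50000 nM to 200000 nM, and is most likely again reported only as a limit.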

Compound 4, minimum cytotoxic concentration: > 100000 nM
Compound 4: no number, only a limit; the forecaster's own chance of this, stated with the estimate: 90%; the middle value sits exactly at the limit.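

In this assay compound 4 gives > 100000 nM, a limit of the assay, so its steps from compounds 1, 2 and 3 cannot be read. The compounds shown leave open at what concentration any of them becomes cytotoxic, and whether 2-chlorophenyl and 3-chlorophenyl differ at all.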